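Adding methoxy to the anilino ring of compound 2

The source may report more compounds than this note shows. Statements on the series, on what has been measured and on what is new or still open speak of the compounds shown alone.

Going by the values given here, in a functional assay on HeLa cells (Homo sapiens) for inhibition, read by sulforhodamine B assay (a lower number here means a stronger inhibitor, a higher number a weaker inhibitor), compound 2 (`O=C1C=C(Nc2ccccc2)C(=O)c2c1nc1n2[C@H]2OC[C@@H](O)[C@H]2OC1`) gives 5620 nM and stands within the scatter of the only other measured compound. That is compound 1 (`COc1ccccc1NC1=CC(=O)c2nc3n(c2C1=O)[C@H]1OC[C@@H](O)[C@H]1OC3`), which shares the core and gives 2950 nM in this assay on the same read-out. Compound 3 (`COc1cccc(NC2=CC(=O)c3nc4n(c3C2=O)[C@H]2OC[C@@H](O)[C@H]2OC4)c1`) has not yet been measured. Its difference from compound 2 is methoxy in place of hydrogen on an aromatic carbon and amounts to methoxy in place of hydrogen on an aromatic carbon, meta to a large group. Among the compounds with values here, only one measured step bears on this change: a 1.9-fold higher number from compound 1 to compound 2 (0.28 log units; within the scatter) and it also concerns a methoxy on the aromatic ring, though at a different place. That step is small and runs in the reverse sense of exchange, so no step beyond the scatter is expected in this assay for this new placement. The estimated 1.5-fold lower number from compound 2 to compound 3 (0.17 log units; within the scatter) leans towards the side of the methoxy-bearing compound 1 but stays within the scatter. For compound 3 the estimated value is 3800 nM with an expected range of 1700 nM to 8500 nM in this measurement.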

Compound 3, half-maximal inhibitory concentration: 4280 nM
Compound 3: the middle estimate sits 1.1-fold (0.05 log units) below what was measured; the range from low to high includes it.
By their numbers in this assay, from the lowest: compounds 1, 3 and 2 (each within the scatter of the next).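

In this assay, the methoxy meta to a large group now has its own measured step: a 1.3-fold lower number from compound 2 to compound 3 (0.12 log units; within the scatter) shows that this placement does not separate from the plain anilino compound. The comparison of the two placements is also new, since 3-methoxyphenyl in place of 2-methoxyphenyl on the amine nitrogen gives a 1.5-fold higher number from compound 1 to compound 3 (0.16 log units; within the scatter) and so the place of the methoxy on this ring makes no difference that can be read here. No measurement of any kind is available to explain why these steps are so small.

The compounds shown leave open whether any other group on this ring, such as a chlorine, an amine or a carboxylic acid, would carry the number beyond the scatter. They also leave open whether a longer chain at the same place, such as ethoxy or butoxy, would do so, as all three compounds here carry either hydrogen or methoxy on the ring.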